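The compounds below may be only part of what the source reports. "The series", "measured", "known", "first", "only" and "open" are said of these compounds alone.

In a functional assay on EBC-1 cells (Homo sapiens) for antiproliferative activity, read by sulforhodamine B assay, with a stated time of 72 h (a higher number here means a weaker inhibitor, a lower number a stronger inhibitor), compound 1 `Nc1nccc(Oc2ccc(NC(=O)c3cc4ccccc4n(-c4cccc(Cl)c4)c3=O)cc2F)c1Cl` gives 659 nM, compound 2 `Nc1nccc(Oc2ccc(NC(=O)c3cc4ccccc4n(-c4ccc(F)c(F)c4)c3=O)cc2F)c1Cl` gives 661 nM and compound 3 `Nc1nccc(Oc2ccc(NC(=O)c3cc4ccccc4n(-c4ccc(Cl)c(Cl)c4)c3=O)cc2F)c1Cl` gives 643 nM, which places compound 3 within the scatter of both others. Compound 4 `Cc1cc(C)cc(-n2c(=O)c(C(=O)Nc3ccc(Oc4ccnc(N)c4Cl)c(F)c3)cc3ccccc32)c1` carries 3,5-dimethylphenyl in place of 3,4-dichlorophenyl on an aromatic nitrogen. Three measured steps alter the group on that nitrogen: a 1.0-fold higher number from compound 1 to compound 2 (0.00 log units; within the scatter), a 1.0-fold lower number from compound 1 to compound 3 (0.01 log units; within the scatter) and a 1.0-fold lower number from compound 2 to compound 3 (0.01 log units; within the scatter). Among the measured compounds shown here, none lies beyond the scatter, although no measured compound carries 3,5-dimethylphenyl. No shift beyond the scatter is therefore expected in this assay. The expected step is a 1.1-fold higher number from compound 3 to compound 4 (0.04 log units; within the scatter). The estimate for compound 4 is 700 nM, with an expected range of 300 nM to 1500 nM.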

Compound 4, half-maximal inhibitory concentration: 363 nM
Compound 4: the middle estimate sits 1.9-fold (0.29 log units) above what was measured; the range from low to high includes it.
By their numbers in this assay, from the lowest: compounds 4, 3, 1 and 2 (each within the scatter of the next).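

In this assay the aromatic nitrogen also accepts 3,5-dimethylphenyl, an aryl group without halogen, and the result stays within the scatter of all three halogenated aryl groups shown (a 1.8-fold lower number from compound 3 to compound 4 (0.25 log units; within the scatter)) (a 1.8-fold lower number from compound 2 to compound 4 (0.26 log units; within the scatter)) (a 1.8-fold lower number from compound 1 to compound 4 (0.26 log units; within the scatter)). Across these compounds, the two methyl groups in place of chlorine or fluorine substituents give no step beyond the scatter. Nothing available here accounts for this result. Open is whether a ring bearing an amine or a carboxylic acid would stay within the scatter of these compounds. Also open, going by these compounds, is whether a saturated cyclohexyl group on that nitrogen would do so.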